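Sulfation of a Hydroxymethyl Group on a Glycolipid Core

This account rests on a few compounds, and the source may have more. Where it says the series, first, only, none or still open, it means among the compounds named here.

Measured compounds:
Compound 1 `CCCCCCCC/C=C\CCCCCCCCO[C@H]1O[C@H](CO)[C@@H](O)[C@H](O)[C@H]1NC(C)=O` — 1.3 uM
Compound 2 `CCCCCCCC/C=C\CCCCCCCCO[C@H]1O[C@H](CO)[C@@H](O)[C@H](OS(=O)(=O)O)[C@H]1NC(C)=O` — 12.3 uM

Of the two compounds measured in a functional assay on C6 cells (Rattus norvegicus), read by thymidine incorporation (on this read-out higher numbers stand for weaker inhibition and lower numbers for stronger inhibition), compound 1 gives the lower number, and compound 2 gives the higher one, a gap that exceeds the scatter of repeated measurements: a 9.5-fold higher number from compound 1 to compound 2 (0.98 log units; beyond the scatter). The change behind that step was a sulfo group in place of a hydrogen on an oxygen on a saturated carbon of the shared core.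

Compound 3 `CCCCCCCC/C=C\CCCCCCCCO[C@H]1O[C@H](COS(=O)(=O)O)[C@@H](O)[C@H](O)[C@H]1NC(C)=O` has not yet been measured. It differs from compound 1 by sulfo in place of hydrogen on an oxygen on a saturated carbon. Within the data shown here, the change is the same kind as the one that separates compound 2 from compound 1, but it sits on the hydroxymethyl group of the core rather than on the ring hydroxy group that was sulfated in compound 2.

Among the measured compounds shown here, only one measured step bears on this change, and it was of modest size. The expectation is therefore that compound 3 will give a higher number than compound 1, of roughly the same size as that step: a 6.2-fold higher number from compound 1 to compound 3 (0.79 log units; beyond the scatter). Compound 3 is estimated at 8 uM, within a range of 2.5 uM to 25 uM.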

Compound 3, concentration for 50% inhibition: 13 uM
For compound 3 the middle estimate is 1.6-fold (0.21 log units) below the measured one; low and high end bracket the measured number.
By their numbers in this assay, from the lowest: compound 1; then compounds 2 and 3 (each within the scatter of the next).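

In this assay, the sulfo group raises the number on the hydroxymethyl group as well, since the change to (sulfooxy)methyl gives a 10-fold higher number from compound 1 to compound 3 (1.00 log units; beyond the scatter). The weakening seen earlier is therefore not confined to a single site on the shared core: compound 2 gives 12.3 uM and compound 3 gives 13 uM, two values within the scatter of each other, so these two compounds do not separate the two places of the sulfo group. Nothing available explains why this change weakens inhibition at either place.

The compounds shown leave open whether the effect belongs to the sulfo group itself or would also appear with a phosphate, an acetyl ester or a methyl ether on the same oxygen, and whether a carboxylic acid in place of the hydroxymethyl group would behave alike. They also leave open how the remaining hydroxy group of the core would respond to sulfation, and what two sulfo groups on one core would do to the number.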